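A few compounds are considered here, and "the series" means these few. Any claim that something is new, unique, unknown or untested is made for them only; others in the source may bear on it.

Compound 1 `CCOC(=O)CN(C(=O)/C(C)=C/c1ccc(C(=O)Oc2ccc(C(=N)N)cc2)cc1)C1CCCCC1` was examined in an in vitro ADME assay on a cell-free system (plasma) for pharmacokinetics; on this read-out higher numbers stand for a longer-lived compound and lower numbers for a shorter-lived compound. In this assay compound 1 gives < 0.0834 h, which is a limit of the assay rather than a measured number. Compound 2 `CCOC(=O)CCCN(C(=O)/C(C)=C/c1ccc(C(=O)Oc2ccc(C(=N)N)cc2)cc1)C(C(=O)OCC)C(=O)OCC` was studied in this assay as well. Here compound 2 gives < 0.0167 h, again only a limit and not a number. Among the compounds with values here, since neither measured compound has a true value, no step between measured compounds can be stated, and the picture so far is simply one of short-lived compounds.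

Compound 3 `CCOC(=O)CN(C(=O)/C(C)=C/c1ccc(C(=O)Oc2ccc(C(=N)N)cc2)cc1)C1CCCC1` has not yet been measured in this assay. It differs from compound 1 by cyclopentyl in place of cyclohexyl on an amide-type nitrogen. Within the data shown here, with no measured step to lean on, the shift in this assay is expected to stay within the usual scatter, with no set direction; the expected shift is a step that the limit leaves unreadable from compound 1 to compound 3. Compound 3 is therefore expected to give about 0.05 h, within a range from 0.02 h to 0.15 h, and may well again be reported only as a limit.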

Compound 3, half-life: < 0.0834 h
Compound 3 was reported as a limit; the forecaster's own chance of this, stated with the estimate: 70%; the middle value is on the limit's open side.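

Compound 1 and compound 3 are both reported in this assay only as limits, so no step between them can be read: the limit of < 0.0834 h in this assay, at which 2 of the 3 values shown sit.

The compounds shown leave open how long any of them truly lasts, and whether cyclopentyl in place of cyclohexyl changes that at all.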